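The source may hold more compounds than are shown below. What is called first, only, known or untested is meant among the compounds shown, and "the series" means these compounds.

Compounds 1 to 4 share one core and differ in a single chain. In a functional assay on LNCaP cells (Homo sapiens) for antiproliferative activity (on this read-out lower numbers stand for stronger inhibition and higher numbers for weaker inhibition), compound 1 (`Cn1ncc(Cl)c1-c1cc(C(=O)N[C@@H]2CN[C@H](CCCO)C[C@H]2c2ccc(Cl)c(Cl)c2)oc1Cl`) gives 210 nM and compound 2 (`Cn1ncc(Cl)c1-c1cc(C(=O)N[C@@H]2CN[C@H](CCN3CCCCC3)C[C@H]2c2ccc(Cl)c(Cl)c2)oc1Cl`) gives 1780 nM. Compound 3 (`CCC[C@@H]1C[C@@H](c2ccc(Cl)c(Cl)c2)[C@H](NC(=O)c2cc(-c3c(Cl)cnn3C)c(Cl)o2)CN1`), which carries propyl, offers no starting point: its entry in this assay reads compound 3 "not determined" (no result reported), so it has no number to step from.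

Compound 4 (`Cn1ncc(Cl)c1-c1cc(C(=O)N[C@@H]2CN[C@H](CCO)C[C@H]2c2ccc(Cl)c(Cl)c2)oc1Cl`) differs from compound 3 by one change, (hydroxy in place of methyl on a saturated chain carbon, two bonds along the chain from a saturated ring carbon). This is hydroxy in place of methyl on a saturated chain carbon, two bonds along the chain from a saturated ring carbon. Cut one bond further out, the same difference reads propyl to 2-hydroxyethyl.

Going by the values given here, only one measured step exists, an 8.5-fold higher number from compound 1 to compound 2 (0.93 log units; beyond the scatter), and it is a different change, piperidin-1-yl in place of hydroxymethyl. It shows that the chain end can move the read-out beyond the scatter, but it does not size this change. With no number for compound 3, no step size or direction can be expected in this assay. The nearest reference is compound 1 at 210 nM, whose chain also ends in hydroxy, so the expectation rests there rather than on the higher value of compound 2.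

The expected value for compound 4 is 300 nM, with an estimated range from 100 nM to 900 nM.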

Compound 4, half-maximal inhibitory concentration: 160 nM
Compound 4: the middle estimate sits 1.9-fold (0.27 log units) above what was measured; measured number inside the range.
By their numbers in this assay, from the lowest: compounds 4 and 1 (each within the scatter of the next); then compound 2.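

In this assay the step of a 1.3-fold lower number from compound 1 to compound 4 (0.12 log units; within the scatter) stays within the scatter, so hydroxy in place of hydroxymethyl at this place leaves compounds 1 and 4 unseparated, and the chain end in both is hydroxy. The step of an 11-fold lower number from compound 2 to compound 4 (1.05 log units; beyond the scatter) lies beyond the scatter and is about as large as the earlier step of an 8.5-fold higher number from compound 1 to compound 2 (0.93 log units; beyond the scatter), which shows that among these three compounds the two hydroxy-ended chains stand together while the chain ending in piperidin-1-yl stands apart. No measurement offered here accounts for this difference.

Steps from compound 3 cannot be read, so what hydroxy in place of methyl does on this saturated chain carbon remains unknown, and the comparison of propyl with 2-hydroxyethyl stays open. The compounds shown also leave open whether a chain ending in a primary amine, a carboxylic acid or a methoxy group would read like compounds 1 and 4 or like compound 2, and so whether piperidin-1-yl stands alone among such chain ends.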